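The compounds below may be only part of what the source reports. "The series", "measured", "known", "first", "only" and "open" are said of these compounds alone.

Measured so far in an assay on isolated protein for inhibition of sodium channel protein type 3 subunit alpha (Homo sapiens), read by electrophysiology, with a stated time of 4 min; on this read-out lower numbers stand for stronger inhibition and higher numbers for weaker inhibition:
Compound 1 `Nc1nc(-c2cccc(NC(=O)c3ccc[nH]3)c2)cn1C(=O)c1ccc[nH]1` gives > 30000 nM, which is a limit of the assay.
Compound 2 `CC(C)(C)OC(=O)n1cc(-c2cccc(NC(=O)c3ccc[nH]3)c2)nc1N` gives > 30000 nM, also a limit of the assay.

Compound 2 therefore stands only at a limit in this assay, not at a number. The step from compound 1 to compound 2 is a step that the two limits leave unreadable from compound 1 to compound 2, unreadable because of the limit of > 30000 nM in this assay, at which 2 of the 2 values shown sit. Compound 3 `CC(C)(C)OC(=O)n1cc(-c2cccc(NC(=O)c3c[nH]c4ccccc34)c2)nc1N` differs from compound 2 by 1H-indol-3-yl in place of 1H-pyrrol-2-yl on a carbonyl carbon. Within the data shown here, no measured step bears on this change, so no direction can be drawn; a further limit seems the likeliest outcome. Compound 3 is expected to give about 30000 nM, between 8000 nM and 100000 nM. The expected step from compound 2 to compound 3 is a number no higher from compound 2 to compound 3 (the limit leaves the size open).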

Compound 3, half-maximal inhibitory concentration: > 30000 nM
Compound 3: no number, only a limit; the forecaster's own chance of this, stated with the estimate: 75%; the middle value lies on the limit itself.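

The step from compound 2 to compound 3 in this assay cannot be read, because both stand only at a limit: the limit of > 30000 nM in this assay, at which 3 of the 3 values shown sit. The compounds shown leave open how strongly any of them inhibits, and whether 1H-indol-3-yl and 1H-pyrrol-2-yl differ at all.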